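The source may hold more compounds than are shown below. What is called first, only, known or untested is meant among the compounds shown, and "the series" means these compounds.

Measured in a functional assay on HeLa cells (Homo sapiens) for inhibition, read by MTT assay, with a stated time of 24 h; on this read-out higher numbers stand for weaker inhibition and lower numbers for stronger inhibition:
- compound 1 `CO/N=C1\C[C@@H](c2ccc(Cl)cc2)N[C@@H](c2ccc(Cl)cc2)[C@@H]1C`: 49000 nM
- compound 2 `CO/N=C1\C[C@@H](c2ccc(F)cc2)N[C@@H](c2ccc(F)cc2)[C@@H]1C`: 49200 nM
- compound 3 `CO/N=C1\C[C@@H](c2ccc(Cl)cc2)N(C)[C@@H](c2ccc(Cl)cc2)[C@@H]1C`: 36300 nM

Compounds 1 and 3 share a core that carries two 4-chlorophenyl groups; compound 2 carries 4-fluorophenyl groups instead, and the difference between the two cores is not broken down here. Compound 2 and compound 1 give numbers that lie within the scatter of each other, as do compound 2 and compound 3.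

The one step measured so far is methyl in place of hydrogen on an amine nitrogen in a ring
It gave a 1.3-fold lower number from compound 1 to compound 3 (0.13 log units; within the scatter).

Compound 4 `CO/N=C1\C[C@@H](c2ccc(F)cc2)N(C)[C@@H](c2ccc(F)cc2)[C@@H]1C` is not yet measured. It stands to compound 2 as compound 3 stands to compound 1: methyl in place of hydrogen on an amine nitrogen in a ring
The two sites differ only in that the neighbouring ring atoms bear a 4-fluorophenyl group rather than a 4-chlorophenyl group, so this is the same kind of change, not the same one.

For the measured compounds named here, for compound 4 in this assay a step of about a 1.3-fold lower number from compound 2 to compound 4 (0.11 log units; within the scatter) is expected, resting on the single earlier step of a 1.3-fold lower number from compound 1 to compound 3 (0.13 log units; within the scatter), which stayed within the scatter. Compound 4 is therefore estimated at 38000 nM, with a range from 19000 nM to 75000 nM.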

Compound 4, half-maximal inhibitory concentration: 40700 nM
For compound 4 the middle estimate is 1.1-fold (0.03 log units) below the measured one, within the range that was stated.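

In this assay, methyl in place of hydrogen on the amine nitrogen in the ring gives a 1.2-fold lower number from compound 2 to compound 4 (0.08 log units; within the scatter). Set beside the earlier step, the change reads alike on the core bearing 4-chlorophenyl groups and the core bearing 4-fluorophenyl groups: the same change on two cores in this assay, a 1.3-fold lower number (0.13 log units; within the scatter) from compound 1 to compound 3 and a 1.2-fold lower number (0.08 log units; within the scatter) from compound 2 to compound 4, 1.1-fold (0.05 log units) apart, within the scatter of two such steps Since each step stays within the scatter, the pair shows only that this change carried over without a measurable shift on either core; it does not show that methyl truly strengthens inhibition, and two closely related cores say nothing about how the change would behave on a more distant core.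

Still open, from the compounds shown here alone, is whether a longer chain such as ethyl, or a benzyl group, on the same nitrogen would move the number beyond the scatter. Equally open, going by these compounds, is whether an unsubstituted phenyl or a 4-methoxyphenyl group in place of the 4-fluorophenyl groups would give a step of a different size.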